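A few compounds are considered here, and "the series" means these few. Any claim that something is new, unique, unknown or untested is made for them only; others in the source may bear on it.

Compound 1 `CSc1nc(SC)c2ncn([C@@H]3C[C@@H](O)[C@H](CO)O3)c2n1` belongs to a small set of nucleosides tested in a functional assay on NALL-1 cells (Homo sapiens); on this read-out higher numbers stand for weaker inhibition and lower numbers for stronger inhibition. In this assay compound 1 gives 173 uM, and the two bromo analogues stand close to it: compound 2 `CN(C)c1nc(Br)nc2c1ncn2[C@@H]1C[C@@H](O)[C@H](CO)O1` gives 290 uM and compound 3 `CNc1nc(Br)nc2c1ncn2[C@@H]1C[C@@H](O)[C@H](CO)O1` gives 230 uM, so all three numbers sit within the usual scatter of one another and no ranking among them can be drawn.

The step to compound 4 `CSc1nc(N)c2ncn([C@@H]3C[C@@H](O)[C@H](CO)O3)c2n1` is amino in place of methylsulfanyl on an aromatic carbon. Going by the values given here, the only measured step in the set, a 1.3-fold lower number from compound 2 to compound 3 (0.10 log units; within the scatter), also touches a substituent on the same position of the shared core, and it stayed within the scatter. That step replaces one nitrogen substituent with another, whereas here a methylsulfanyl gives way to an amino, so its bearing is loose. Among the compounds with values here, still, nothing among the measured compounds points to a shift beyond the scatter. The expected step is a 1.1-fold lower number from compound 1 to compound 4 (0.03 log units; within the scatter). Compound 4 is therefore estimated at 160 uM, within a range from 55 uM to 470 uM.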

Compound 4, concentration for 50% inhibition: 96 uM
The estimate for compound 4 lay 1.7-fold (0.22 log units) above the measured number, within the range that was stated.
By their numbers in this assay, from the lowest: compounds 4, 1, 3 and 2 (each within the scatter of the next, the first and the last beyond it).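

In this assay, going by these compounds alone, the exchange at this aromatic carbon gives a 1.8-fold lower number from compound 1 to compound 4 (0.26 log units; within the scatter) and so offers the first direct reading of this position, with the other methylsulfanyl group left in place. Replacing methylsulfanyl with amino, and so a sulfur-bearing group with a smaller nitrogen group that brings a hydrogen-bond donor, therefore produces no change that can be told from the scatter.

From the compounds shown here alone, whether a hydroxyl group or a longer chain such as ethylsulfanyl on this carbon would carry the number beyond the scatter remains open. So does whether amino would behave the same way with bromo in place of the remaining methylsulfanyl group, and no available evidence bears on the reason for this result.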